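The source may hold more compounds than are shown below. What is called first, only, known or untested is meant among the compounds shown, and "the series" means these compounds.

Measured compounds in an ADME assay on a cell-free system (plasma, Homo sapiens) for metabolic stability, read by HPLC, tested at 5 mM; a higher number here means that the compound lasts longer, a lower number that the compound disappears faster:
compound 1, `C[C@@H](O)[C@H]1C(=O)N2C(C(=O)OCOC(=O)OC3Cc4ccccc4C3)=C(S[C@@H]3CN[C@H](C(=O)N(C)C)C3)[C@H](C)[C@H]12`, gives 0.0717 h
compound 2, `C[C@@H](O)[C@H]1C(=O)N2C(C(=O)OCOC(=O)O[C@H]3CCCCc4ccccc43)=C(S[C@@H]3CN[C@H](C(=O)N(C)C)C3)[C@H](C)[C@H]12`, gives 0.733 h

Compound 1 stands lowest of the two numbers in this assay; its nearest neighbour is compound 2, and the step of a 10-fold higher number from compound 1 to compound 2 (1.01 log units; beyond the scatter) lies well beyond the scatter. The unmeasured compound 3, `C[C@@H](O)[C@H]1C(=O)N2C(C(=O)OCOC(=O)OC3CCc4ccccc4C3)=C(S[C@@H]3CN[C@H](C(=O)N(C)C)C3)[C@H](C)[C@H]12`, differs from compound 1 in one place: 1,2,3,4-tetrahydronaphthalen-2-yl in place of 2,3-dihydro-1H-inden-2-yl on an oxygen next to a carbonyl group. Among the measured compounds shown here, the only measured step that bears on this change is the one from compound 1 to compound 2, where a seven-membered non-aromatic ring of carbon only took the place of the five-membered one on the oxygen next to a carbonyl group, and it was large: a 10-fold higher number from compound 1 to compound 2 (1.01 log units; beyond the scatter). Compound 3 carries a six-membered non-aromatic ring of carbon only, a ring size that lies between the two measured cases, so a rise in this assay beyond the scatter is expected, though a smaller one than that seen for compound 2. Compound 3 is therefore expected to give 0.25 h, between 0.1 h and 0.65 h, which amounts to an expected step of a 3.5-fold higher number from compound 1 to compound 3 (0.54 log units; beyond the scatter).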

Compound 3, half-life in the plasma assay: 0.135 h
Compound 3: middle estimate off by 1.9-fold (0.27 log units), on the high side, within the range that was stated.
By their numbers in the plasma assay, from the lowest: compounds 1 and 3 (each within the scatter of the next); then compound 2.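

In the plasma assay, 1,2,3,4-tetrahydronaphthalen-2-yl in place of 2,3-dihydro-1H-inden-2-yl on an oxygen next to a carbonyl group gives a 1.9-fold higher number from compound 1 to compound 3 (0.27 log units; within the scatter), so the six-membered non-aromatic ring cannot be told from the five-membered one at this position, while a 5.4-fold lower number from compound 2 to compound 3 (0.73 log units; beyond the scatter) keeps compound 2, with its seven-membered ring, apart from both. The same change gives no separation in a physicochemical assay for metabolic stability, read by HPLC, in simulated gastric fluid, at pH 1.2, tested at 100 uM (a higher number here means that the compound lasts longer, a lower number that the compound disappears faster), either: there compound 1 gives 0.217 h and compound 3 gives 0.233 h, which is a 1.1-fold higher number from compound 1 to compound 3 (0.03 log units; within the scatter). No measurement at hand offers an explanation for what sets compound 2 apart.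

A single compound carries the seven-membered ring, so these compounds leave open whether that ring itself or some other feature of the group on this oxygen goes with the higher number. They also leave open how an open longer chain, or an amine or a carboxylic acid on the aromatic ring of the group, would behave at this position in the plasma assay.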